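The source may report more compounds than this note shows. Statements on the series, on what has been measured and on what is new or still open speak of the compounds shown alone.

Measured so far in an ADME assay on microsomes from liver (Mus musculus) for metabolic stability, read by LC-MS, with a stated time of 30 min, tested at 1 uM; a higher number here means that more of the compound is left, a lower number that less of the compound is left:
compound 1 `O=C(NCc1ccc(S(=O)(=O)c2ccccc2)cc1)c1cc(-c2cccnc2)[nH]n1` gives 42%
compound 2 `O=C(NCc1ccc(S(=O)(=O)c2ccccc2)cc1)c1cc2ncccc2s1` gives 1.6%
compound 3 `O=C(NCc1ccc(S(=O)(=O)c2ccccc2C(F)(F)F)cc1)c1cc2cnccc2[nH]1` gives 41%

Compound 2 stands lowest of the three numbers in this assay; compound 3 is the nearest to it and compound 1 the furthest, and both gaps lie beyond the scatter. Compound 4 `O=C(NCc1ccc(S(=O)(=O)c2ccccc2)cc1)c1cnc2nccn2c1` is not yet measured. It differs from compound 2 in one place: a group of 9 heavy atoms (6 carbon, 3 nitrogen; one five-membered aromatic ring with 2 hetero atoms, one six-membered aromatic ring with 2 hetero atoms) in place of a group of 9 heavy atoms (7 carbon, 1 nitrogen, 1 sulfur; one five-membered aromatic ring with 1 hetero atom, one six-membered aromatic ring with 1 hetero atom), on a carbonyl carbon. Going by the values given here, no two measured compounds differ in only one place, so no measured step guides this change. The other two amides, compound 1 at 42% and compound 3 at 41%, sit far above compound 2, and the estimate leans on that. The step is expected to go upward, beyond the scatter, by a number 28.4 percentage points higher from compound 2 to compound 4 (beyond the scatter). Compound 4 is expected to give 30% in this assay, within 8% to 60%.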

Compound 4, percent of the compound remaining: 30%
The estimate for compound 4 equals the measured number at the digits printed; measured number inside the range.
By their numbers in this assay, from the lowest: compound 2; then compound 4; then compounds 3 and 1 (each within the scatter of the next).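

In this assay the exchange on the carbonyl carbon gives a number 28.4 percentage points higher from compound 2 to compound 4 (beyond the scatter) with the rest of the molecule held constant. The low number of compound 2 therefore does not belong to the shared remainder alone, and this place on its own can move the read-out beyond the scatter. Nothing at hand ties the step to the loss of sulfur, the added nitrogens or any other feature of the two groups.

Open, from the compounds shown here alone, is how a single ring, such as plain phenyl, would behave on this carbonyl carbon. Also open, going by these compounds, is whether the same exchange would hold with a trifluoromethyl group on the phenyl sulfone.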